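The compounds below may be only part of what the source reports. "The series", "measured", "known", "first", "only" and "open" are said of these compounds alone.

Compound 1 `CCCCCc1cc(-c2cn([C@H]3C[C@H](OC(C)=O)[C@@H](COC(C)=O)O3)c(=O)[nH]c2=O)on1` carries a pentyl group on the five-membered aromatic ring with one nitrogen and one oxygen. In a functional assay on NCI-H23 cells (Homo sapiens) for cytotoxicity, read by sulforhodamine B assay, tested at 10 uM (a higher number here means more inhibition at the concentration tested (going by the name of the read-out), a lower number less inhibition), compound 1 gives 88.9%. Compound 2 `CC(=O)OC[C@H]1O[C@@H](n2cc(-c3cn(Cc4ccc(C(C)C)cc4)nn3)c(=O)[nH]c2=O)C[C@@H]1OC(C)=O` gives 86.7% in this assay. Of these two numbers compound 1 stands highest, yet the gap to compound 2 lies within the scatter, so the two readings cannot be placed in order. Compound 3 `CC(=O)OC[C@H]1O[C@@H](n2cc(-c3cc(-c4ccccc4)no3)c(=O)[nH]c2=O)C[C@@H]1OC(C)=O` has not yet been measured. Its change from compound 1 is phenyl in place of pentyl on an aromatic carbon. Read one bond further out, the change runs from 3-pentyl-1,2-oxazol-5-yl to 3-phenyl-1,2-oxazol-5-yl. Among the measured compounds shown here, no pair of measured compounds separated by a single change exists in this set, so the size of such a step cannot be taken from measured data. Both measured compounds give high inhibition despite differing considerably in their outer groups, which offers some ground for expecting a modest outcome here. The expected step of a number 6.9 percentage points lower from compound 1 to compound 3 (within the scatter) is small, in the downward direction, and within the scatter. Compound 3 is expected to give 82%, between 55% and 95%.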

Compound 3, a percentage reported as inhibition, at one concentration (the size of the read-out at that concentration, not a potency): 91.4%
Estimate against measurement, compound 3: 9.4 percentage points below, and the stated range covers the measured number.
By their numbers in this assay, from the lowest: compounds 2, 1 and 3 (each within the scatter of the next).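

In this assay, among the compounds shown here, placing phenyl instead of pentyl on the aromatic carbon next to the ring nitrogen gives a number 2.5 percentage points higher from compound 1 to compound 3 (within the scatter), the first step in this set that can be read between compounds differing in one place. At this position, then, a pentyl chain and a phenyl ring cannot be told apart by this read-out, which reflects the size of the response at one concentration and not a potency, so the result says nothing about whether the two compounds would separate at lower concentrations. Nothing in the available data accounts for this result.

Both groups compared here contain carbon only and have no hydrogen-bond donors or acceptors, so the compounds shown leave open whether an amine or a carboxylic acid on the same aromatic carbon would keep the reading at this level. They also leave open how a much shorter chain such as methyl would read at this position, and whether a longer chain than pentyl would read the same.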